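The source may report more compounds than this note shows. Statements on the series, on what has been measured and on what is new or still open speak of the compounds shown alone.

Measured so far in a functional assay on the whole organism (strain Sprague-Dawley) with Rattus norvegicus as the target, read by paw edema, with a stated time of 3 h, at a dose of 50 mg/kg by the oral route; a higher number here means more inhibition at the dose given (going by the name of the read-out), a lower number less inhibition:
compound 1, `CSc1ncc(-c2ccc(S(C)(=O)=O)cc2)n1-c1ccc(Cl)cc1`, gives 59.5%
compound 2, `CSc1ncc(-c2ccc(S(C)(=O)=O)cc2)n1-c1ccc(Br)cc1`, gives 90.7%

Compound 2 stands highest of the two numbers in this assay; the nearest is compound 1, with a number 31.2 percentage points higher from compound 1 to compound 2 (beyond the scatter). For the measured compounds named here, that exchange of a halogen for a halogen on the same aromatic carbon is the only measured step.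

Compound 3, `COc1ccc(-n2c(-c3ccc(S(C)(=O)=O)cc3)cnc2SC)cc1`, is not yet measured. It differs from compound 2 by methoxy in place of bromo on an aromatic carbon. Going by the values given here, no measured step exchanges a halogen for methoxy, so the step from compound 1 to compound 2 bears on the change only loosely: it shows that a small change at this position moved the read-out well beyond the scatter, not in which direction methoxy would move it. With the two measured numbers as the only anchors, a downward step of moderate size, a number 25.7 percentage points lower from compound 2 to compound 3 (beyond the scatter), is expected, with wide uncertainty. Compound 3 is therefore estimated at 65%, with a range from 35% to 90%.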

Compound 3, a percentage reported as inhibition, in the whole organism at one dose (the size of the read-out at that dose, not a potency): 41.3%
Estimate against measurement, compound 3: 23.7 percentage points above, within the range that was stated.
By their numbers in this assay, from the lowest: compound 3; then compound 1; then compound 2.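

In this assay, methoxy in place of bromo gives a number 49.4 percentage points lower from compound 2 to compound 3 (beyond the scatter), and methoxy in place of chloro gives a number 18.2 percentage points lower from compound 1 to compound 3 (beyond the scatter). The direction that the halogen exchange could not show is now measured for this one group: compound 3 stands lowest of the three, below both halogen compounds, and each step among the three lies beyond the scatter. No measurement shown here accounts for the order of bromo, chloro and methoxy on this aromatic carbon.

Going by these compounds, what remains open is how an amine, a carboxylic acid or an ethoxy group at this place would compare with bromo and methoxy. On these data alone, each number also reflects a single oral dose and time point, so whether the same order would hold at other doses remains open.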